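Mirror Image of a Hydroxycyclohexyl Kinase Inhibitor

A few compounds are considered here, and "the series" means these few. Any claim that something is new, unique, unknown or untested is made for them only; others in the source may bear on it.

Three compounds share one core and were tested in an assay on isolated protein for inhibition of protein kinase C delta type (Homo sapiens), read by TR-FRET, with a stated time of 2 h; on this read-out lower numbers stand for stronger inhibition and higher numbers for weaker inhibition. Compound 1 `N#Cc1cnc(NCc2cnccc2C(F)(F)F)cc1NC[C@H]1C[C@@H](O)C1` gives 4200 nM in this assay. Compound 2 `N#Cc1cnc(NCc2cnccc2C(F)(F)F)cc1NC[C@H]1CC[C@@H](O)CC1` gives 500 nM, and compound 3 `CC1(C)C[C@H](Nc2cc(NCc3cnccc3C(F)(F)F)ncc2C#N)CC[C@@H]1O` gives 500 nM. Compound 3 stands level with compound 2 at the digits shown, and together they hold the lowest numbers of the three. The two steps that move the number are an 8.4-fold lower number from compound 1 to compound 2 (0.92 log units; beyond the scatter) and an 8.4-fold lower number from compound 1 to compound 3 (0.92 log units; beyond the scatter), whereas between the two larger rings there is no change at the digits printed from compound 2 to compound 3 (within the scatter).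

Compound 4 `CC1(C)C[C@@H](Nc2cc(NCc3cnccc3C(F)(F)F)ncc2C#N)CC[C@H]1O` is next. Compared with compound 3, (the two compounds have the same atoms and bonds and differ only in configuration as drawn: 2 of 2 stereo elements differ (all stereocentres are inverted: mirror images); a stereocentre at a saturated ring carbon is drawn R in compound 3 and S in compound 4; a stereocentre at a saturated ring carbon is drawn S in compound 3 and R in compound 4). Among the compounds with values here, none of the measured steps touches configuration: each of them exchanges one ring for another, and compound 2 and compound 3 show only that the two larger rings sit together within the scatter. So nothing measured here says how much a mirror image shifts this assay, and a change beyond the scatter in either direction remains possible. On that basis the step is estimated as a 3.0-fold higher number from compound 3 to compound 4 (0.48 log units; beyond the scatter), leaning towards a weaker result. Compound 4 is therefore expected to give about 1500 nM in this assay, with a range from 300 nM to 8000 nM.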

Compound 4, half-maximal inhibitory concentration: 2400 nM
Compound 4: middle estimate off by 1.6-fold (0.20 log units), on the low side; low and high end bracket the measured number.
By their numbers in this assay, from the lowest: compounds 2 and 3 (each within the scatter of the next); then compounds 4 and 1 (each within the scatter of the next).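

Configuration at this position clearly counts: in this assay, inverting both stereocentres of the 4-hydroxy-3,3-dimethylcyclohexyl group gives a clear shift (a 4.8-fold higher number from compound 3 to compound 4 (0.68 log units; beyond the scatter)), and that shift can be traced to the arrangement in space alone because nothing else separates the pair: (the fact that compounds 3 and 4 differ only in the configuration as drawn). The ring exchanges seen earlier could not show this, and the mirror image does not share the standing of compound 3 when set against the same neighbours: the step from compound 2 now lies beyond the scatter (a 4.8-fold higher number from compound 2 to compound 4 (0.68 log units; beyond the scatter)), while the step from compound 1 stays within it (a 1.8-fold lower number from compound 1 to compound 4 (0.24 log units; within the scatter)). In this small set, then, the 4-hydroxy-3,3-dimethylcyclohexyl group matches the result of compound 2 only in the configuration drawn for compound 3, so the name of the ring alone does not settle the number.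

The compounds shown leave open which of the two stereocentres carries the shift, since inverting only one of them would be needed to separate their contributions. They also leave open whether the gap of this mirror-image pair would persist with an amine in place of the hydroxy group.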